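A few compounds are considered here, and "the series" means these few. Any claim that something is new, unique, unknown or untested is made for them only; others in the source may bear on it.

Measured compounds: compound 1 `Cc1cc(Nc2cc(-c3ccccc3)[nH]n2)n2nc(SCc3csc4ccccc34)nc2n1` with 2280 nM in a functional assay on MGC-803 cells (Homo sapiens) for inhibition, read by MTT assay, with a stated time of 72 h; on this read-out higher numbers stand for weaker inhibition and lower numbers for stronger inhibition; compound 2 `Cc1cc(Nc2ccn(Cc3nc(C)c4ccccc4n3)n2)n2nc(SCc3ccc(Br)cc3)nc2n1` with 960 nM in this assay.

Compound 1 carries the higher of the two numbers, and its gap from compound 2 lies beyond the scatter. Compound 3 `Cc1cc(Nc2cc(-c3ccccc3)[nH]n2)n2nc(SCc3ccccc3Br)nc2n1` is derived from compound 1 by one change: 2-bromophenyl in place of 1-benzothiophen-3-yl on a saturated chain carbon bound to a sulfur. For the measured compounds named here, no pair of measured compounds isolates this change, and compound 2 differs from compound 1 in several places at once, so the direction can only be guessed. For compound 3 a small step is expected, a 1.3-fold lower number from compound 1 to compound 3 (0.10 log units; within the scatter), probably not beyond the scatter. Compound 3 is therefore estimated at 1800 nM, within a range of 700 nM to 4500 nM.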

Compound 3, half-maximal inhibitory concentration: 3650 nM
The estimate for compound 3 lay 2.0-fold (0.31 log units) below the measured number; low and high end bracket the measured number.
By their numbers in this assay, from the lowest: compound 2; then compounds 1 and 3 (each within the scatter of the next).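

Replacing 1-benzothiophen-3-yl with 2-bromophenyl on a saturated chain carbon bound to a sulfur gives a 1.6-fold higher number from compound 1 to compound 3 (0.20 log units; within the scatter) in this assay, so the two groups cannot be told apart here. At this position, a group with one five-membered and one six-membered aromatic ring and a group with one six-membered aromatic ring and a bromine therefore give numbers within the scatter of each other. No measured evidence bears on the reason for this result.

The compounds shown leave open whether an amine or a carboxylic acid at this place would shift the number beyond the scatter. They also leave open whether a longer chain to the 2-bromophenyl would do so.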